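This account rests on a few compounds, and the source may have more. Where it says the series, first, only, none or still open, it means among the compounds named here.

Working notes on the series. In an assay on isolated protein for displacement of a labelled ligand from Adrenergic receptor alpha-1 (Rattus norvegicus) (on this read-out lower numbers stand for stronger inhibition and higher numbers for weaker inhibition), compound 1 `CCN(CC)C(=O)C1CCN(c2nc(N)c3cc(OC)c(OC)cc3n2)CC1` gives 1.11 nM. It stands second highest of the three numbers: nearest is compound 3 `COc1cc2nc(N3CCC(C(=O)NCCOc4ccccc4)CC3)nc(N)c2cc1OC` with 0.42 nM, furthest compound 2 `CCN(CC)C(=O)C1CCCN(c2nc(N)c3cc(OC)c(OC)cc3n2)C1` with 117 nM. Compound 4 `CCCCNC(=O)CCC1CCN(c2nc(N)c3cc(OC)c(OC)cc3n2)CC1` is not yet measured; it differs from compound 1 by 2-(butylcarbamoyl)ethyl in place of diethylcarbamoyl on a saturated ring carbon. Within the data shown here, the only measured step at the carbonyl side of the shared core is a 2.6-fold lower number from compound 1 to compound 3 (0.42 log units; beyond the scatter), where a secondary amide with a longer substituent took the place of diethylamino. Among the measured compounds shown here, the change to compound 4 also brings in a secondary amide and a longer chain, so a step of similar modest size toward a lower number is expected, a 1.4-fold lower number from compound 1 to compound 4 (0.14 log units; within the scatter), though the chain between ring and carbonyl has no measured precedent. Compound 4 is expected at 0.8 nM, range 0.25 nM to 3.5 nM.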

Compound 4, inhibition constant: 0.47 nM
Beside the measured number, compound 4's estimate is 1.7-fold (0.23 log units) above it; the measured number falls inside the stated range.
By their numbers in this assay, from the lowest: compounds 3 and 4 (each within the scatter of the next); then compound 1; then compound 2.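

On a saturated ring carbon, 2-(butylcarbamoyl)ethyl in place of diethylcarbamoyl gives a 2.4-fold lower number from compound 1 to compound 4 (0.37 log units; beyond the scatter) in this assay. This position therefore accepts a longer group that carries a hydrogen-bond donor and has the carbonyl further along the chain, with a step of modest size, as in a 2.6-fold lower number from compound 1 to compound 3 (0.42 log units; beyond the scatter). No measurement at hand accounts for the step.

Going by these compounds, the chain and the amide change together here, so the share of each remains open. On these data alone, how a carboxylic acid or a longer chain would read at this position is also open.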